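The source may report more compounds than this note shows. Statements on the series, on what has been measured and on what is new or still open speak of the compounds shown alone.

Working notes on the series. The three measured compounds share one core and differ only in the substituent on the aryl ketone: compound 1 `O=C(/C=C/c1ccc(OCc2cn(Cc3ccccc3Br)nn2)cc1)c1ccc(Br)cc1` carries a bromo group there, compound 2 `COc1ccc(C(=O)/C=C/c2ccc(OCc3cn(Cc4ccccc4Br)nn3)cc2)cc1` a methoxy group, compound 3 `O=C(/C=C/c1ccc(OCc2cn(Cc3ccccc3Br)nn2)cc1)c1ccc([N+](=O)[O-])cc1` a nitro group. In a functional assay on A549 cells (Homo sapiens) for inhibition, read by MTT assay, with a stated time of 48 h, tested at 10 uM (on this read-out lower numbers stand for less inhibition of growth and higher numbers for more inhibition of growth at the one concentration tested), compound 1 gives 44%, compound 2 gives 52% and compound 3 gives 42%. The steps among them are a number 8 percentage points higher from compound 1 to compound 2 (within the scatter), a number 2 percentage points lower from compound 1 to compound 3 (within the scatter) and a number 10 percentage points lower from compound 2 to compound 3 (within the scatter), so the three numbers sit together and compound 3 cannot be set apart from compound 1 or compound 2 on these data.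

Compound 4 `O=C(/C=C/c1ccc(OCc2cn(Cc3ccc(F)cc3)nn2)cc1)c1ccc([N+](=O)[O-])cc1` is not yet measured. It differs from compound 3 by 4-fluorophenyl in place of 2-bromophenyl on a saturated chain carbon bound to an aromatic nitrogen. None of the three measured steps touches this part of the molecule; all of them change the group on the aryl ketone and all lie within the scatter. For the measured compounds named here, there is therefore no measured step that bears on the change from compound 3 to compound 4, and no size of step in this assay can be read from the series. The expectation is a step of no change at the digits printed from compound 3 to compound 4 (within the scatter), that is none beyond the scatter. Compound 4 is expected to give 42%, in the range 28% to 58%.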

Compound 4, percent growth inhibition at one concentration: 34%
Compound 4: middle estimate off by 8 percentage points, on the high side; the range from low to high includes it.
By their numbers in this assay, from the lowest: compounds 4, 3, 1 and 2 (each within the scatter of the next, the first and the last beyond it).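

For the compounds shown here, the exchange of 2-bromobenzyl for 4-fluorobenzyl gives, in this assay, a number 8 percentage points lower from compound 3 to compound 4 (within the scatter), and this is the first reading at this position, since the earlier steps all lay on the aryl ketone. It shows that, with a nitro group on the aryl ketone, this exchange on a saturated chain carbon bound to an aromatic nitrogen does not separate the two compounds beyond the scatter, though the halogen and its place on the phenyl ring both differ, so the step cannot be divided between them. No measured property bears on this step, and the data offer no explanation for it.

From the compounds shown here alone, what stays open is whether 4-bromobenzyl or 2-fluorobenzyl, each keeping one feature of the two groups compared here, would read differently, and whether an unsubstituted benzyl, a phenethyl chain or an aminoethyl group would hold the number in the same range. Also open is how 4-fluorobenzyl reads with the bromo or methoxy group on the aryl ketone, and how any of these compounds behave at other concentrations.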